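The compounds below may be only part of what the source reports. "The series", "measured", "known", "first", "only" and "open" are said of these compounds alone.

Measured so far:
- compound 1 `CCCOc1cccnc1-c1ccc(C(=O)Nc2ccc(C(C)(C)C)cc2)cc1`: 20 nM
- compound 2 `CC(C)(C)c1ccc(NC(=O)c2ccc(-c3ncccc3NC3CCCC3)cc2)cc1`: 44 nM
- compound 3 `CC(C)(C)c1ccc(NC(=O)c2ccc(-c3ncccc3N(S(C)(=O)=O)S(C)(=O)=O)cc2)cc1`: 0.4 nM

All three share one core and differ only in a single group on the pyridine-like ring. In a functional assay for antagonist activity at transient receptor potential cation channel subfamily V member 1 (Rattus norvegicus) (on this read-out lower numbers stand for stronger inhibition and higher numbers for weaker inhibition), compound 3 gives 0.4 nM, the lowest of the three numbers; the nearest is compound 1 and the furthest compound 2, so compound 3 is the strongest inhibitor among them.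

Compound 4 `CC(C)(C)c1ccc(NC(=O)c2ccc(-c3ncccc3C(=N)N)cc2)cc1` has not yet been measured. It differs from compound 3 by a group of 3 heavy atoms (1 carbon, 2 nitrogen; no ring) in place of a group of 9 heavy atoms (2 carbon, 1 nitrogen, 4 oxygen, 2 sulfur; no ring), on an aromatic carbon, placed on an aromatic carbon of a six-membered aromatic ring with 1 nitrogen, two atoms from the ring nitrogen.

Among the compounds with values here, two measured steps bear on this: a 50-fold lower number from compound 1 to compound 3 (1.70 log units; beyond the scatter) and a 110-fold lower number from compound 2 to compound 3 (2.04 log units; beyond the scatter). Both show that the bis(methylsulfonyl)amino group is what sets compound 3 apart. Taking it away, even for a group carrying hydrogen-bond donors, is therefore expected to undo most of that gain. For compound 4 the expected step is a 100-fold higher number from compound 3 to compound 4 (2.00 log units; beyond the scatter). The estimate for compound 4 in this assay is 40 nM, with a likely range from 8 nM to 200 nM.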

Compound 4, half-maximal inhibitory concentration: > 4000 nM
Compound 4: no number, only a limit; the forecaster's own chance of this, stated with the estimate: 5%; middle value at least 100-fold (2.00 log units) away from the limit.
By their numbers in this assay, from the lowest: compound 3; then compound 1; then compound 2. At a limit, above all of these: compound 4.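

In this assay compound 4 gives > 4000 nM, which is a limit of the assay and not a number. The change does more than give up the advantage of the bis(methylsulfonyl)amino group, with an at least 10000-fold higher number from compound 3 to compound 4 (4.00 log units; beyond the scatter), for the new group also ends up well behind the weaker groups, with an at least 200-fold higher number from compound 1 to compound 4 (2.30 log units; beyond the scatter) and an at least 90-fold higher number from compound 2 to compound 4 (1.95 log units; beyond the scatter). The three earlier compounds all gave measured values with quite different groups on this aromatic carbon, and compound 4 now shows that this position does not accept every group.

A single compound cannot tell whether the size of the new group, its atoms or its hydrogen-bond donors account for the loss. Still open, as far as these compounds go, is how a nitrile, a carboxamide or a single methylsulfonylamino group would behave at this position.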